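The source may report more compounds than this note shows. Statements on the series, on what has been measured and on what is new or still open speak of the compounds shown alone.

Working notes on the series.

Compound 1 `O=C/C=C/c1ccccc1OCc1ccccc1` is the parent of the pair measured so far. In a functional assay on cells (Neutrophil, Rattus norvegicus, strain Sprague-Dawley) for inhibition (a lower number here means a stronger inhibitor, a higher number a weaker inhibitor), compound 1 gives 6400 nM. Compound 2 `Cc1ccc(COc2ccccc2/C=C/C=O)cc1` carries a methyl on the benzylic ring, and in this assay compound 2 gives 11000 nM. Going by the values given here, the only measured step, a 1.7-fold higher number from compound 1 to compound 2 (0.24 log units; within the scatter), is within the scatter, so the two compounds cannot be ordered against each other. Among the compounds with values here, compound 2 stands as the higher of the two numbers, with compound 1 as its only neighbour, the gap between them being within the scatter.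

Compound 3 `COc1ccc(COc2ccccc2/C=C/C=O)cc1` is not yet measured. Its difference from compound 2 is methoxy in place of methyl on an aromatic carbon. Within the data shown here, the one measured step that bears on this position, from compound 1 to compound 2, changed the same aromatic carbon and moved the number within the scatter. Among the measured compounds shown here, no measured step involves a methoxy at this or any other position, so the expectation rests on that single small step alone. A change within the scatter of compound 2 is therefore expected, with no direction to it beyond that.

On this basis, compound 3 is expected to give about 11000 nM in this assay, in a range from 4000 nM to 30000 nM. The step this implies, no change at the digits printed from compound 2 to compound 3 (within the scatter), is expected to be within the scatter.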

Compound 3, half-maximal inhibitory concentration: 3800 nM
The estimate for compound 3 lay 2.9-fold (0.46 log units) above the measured number; measured number below the stated range.
By their numbers in this assay, from the lowest: compounds 3, 1 and 2 (each within the scatter of the next, the first and the last beyond it).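

In this assay, going by these compounds alone, methoxy in place of methyl on this aromatic carbon, para to a large group, gives a 2.9-fold lower number from compound 2 to compound 3 (0.46 log units; beyond the scatter) and is the first step to lie beyond the scatter, so the choice of group at this carbon can shift the number. Set against the parent, the same position gives a 1.7-fold lower number from compound 1 to compound 3 (0.23 log units; within the scatter) and remains within the scatter, which means neither methoxy nor methyl separates from hydrogen here; only the two substituted compounds separate from each other. Nothing at hand bears on what lies behind the difference between methoxy and methyl.

Still open, from the compounds shown here alone, is whether the gap between compound 2 and compound 3 extends to other groups on this carbon, such as an ethoxy, a hydroxyl, an amine or a chlorine, and whether any of them would separate from compound 1. Also open, going by these compounds, is whether a methoxy on another carbon of the same ring would read like compound 3 or like compound 1.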